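The source may hold more compounds than are shown below. What is called first, only, known or untested is meant among the compounds shown, and "the series" means these compounds.

Working notes on the series. Three compounds sharing one core have numbers in an assay on microsomes from brain for inhibition of Fatty-acid amide hydrolase 1 (Rattus norvegicus), read by fluorescence and HPLC, with a stated time of 60 min; a lower number here means a stronger inhibitor, a higher number a weaker inhibitor. Compound 1 `CCCCCCCCc1ccc(OCC(=O)Cn2nnnc2SC)cc1` gives 22 nM. Compound 2 `CCCCCCCCc1ccc(OCC(=O)Cn2nnnc2-c2ccc(S(=O)(=O)N(C)C)cc2)cc1` gives 1400 nM. Compound 3 `CCCCCCCCc1ccc(OCC(=O)Cn2nnnc2-c2ccncc2)cc1` gives 190 nM, which places it second highest of the three: its nearest neighbour is compound 2, the furthest is compound 1. The steps already seen are a 64-fold higher number from compound 1 to compound 2 (1.80 log units; beyond the scatter), an 8.6-fold higher number from compound 1 to compound 3 (0.94 log units; beyond the scatter) and a 7.4-fold lower number from compound 2 to compound 3 (0.87 log units; beyond the scatter).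

The next compound is compound 4 `CCCCCCCCc1ccc(OCC(=O)Cn2nnnc2C(=O)OCC)cc1`. Relative to compound 3 the change is ethoxycarbonyl in place of pyridin-4-yl on an aromatic carbon, on an aromatic carbon of a five-membered aromatic ring with 4 nitrogen, between two ring nitrogen atoms.

What bears on this step is the contrast between the small methylsulfanyl group of compound 1 and the two six-membered rings of compound 2 and compound 3: the step of an 8.6-fold higher number from compound 1 to compound 3 (0.94 log units; beyond the scatter) and the step of a 64-fold higher number from compound 1 to compound 2 (1.80 log units; beyond the scatter) both went toward higher numbers when a ring entered at this carbon. Ethoxycarbonyl carries no ring and is closer in size to methylsulfanyl, so compound 4 is expected to move back toward compound 1, estimated as a 3.2-fold lower number from compound 3 to compound 4 (0.50 log units; beyond the scatter), a modest step beyond the scatter toward a lower number. The estimated value for compound 4 in this assay is 60 nM, with a range from 15 nM to 300 nM.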

Compound 4, half-maximal inhibitory concentration: 940 nM
Compound 4: the middle estimate sits 16-fold (1.19 log units) below what was measured; measured number above the stated range.
By their numbers in this assay, from the lowest: compound 1; then compound 3; then compounds 4 and 2 (each within the scatter of the next).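

Ethoxycarbonyl carries no ring, yet in this assay it gives a 43-fold higher number from compound 1 to compound 4 (1.63 log units; beyond the scatter), and a 4.9-fold higher number from compound 3 to compound 4 (0.69 log units; beyond the scatter), so the presence of a ring at this carbon does not by itself separate compound 1 from the others, and pyridin-4-yl, a ring, goes against any rule that ring-free groups give the lower numbers. With a 1.5-fold lower number from compound 2 to compound 4 (0.17 log units; within the scatter), the ring-free ethoxycarbonyl and the much larger 4-(dimethylsulfamoyl)phenyl cannot be told apart, so among the four compounds only methylsulfanyl gives a number in the low range, and the groups at this carbon do not fall into order by the presence or absence of a ring. No measurement shown here accounts for the difference among these groups.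

The compounds shown leave open whether the low number of compound 1 belongs to methylsulfanyl alone or extends to ethylsulfanyl, methoxy or a plain methyl on this carbon. They also leave open whether a carboxylic acid or a primary amide in place of ethoxycarbonyl would stay with compound 4 or move toward compound 1.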